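The compounds below may be only part of what the source reports. "The series", "measured", "known", "first", "only" and "open" are said of these compounds alone.

Measured so far in a functional assay on MDA-MB-231 cells (Homo sapiens) for antiproliferative activity, with a stated time of 48 h; on this read-out higher numbers stand for weaker inhibition and lower numbers for stronger inhibition:
- Compound 1 `CCN(CC)c1ccc(-c2cccc(OC)c2)nn1`: > 25000 nM, a limit.
- Compound 2 `CCN(CC)c1ccc(-c2cccc(C(F)(F)F)c2)nn1`: > 25000 nM, a limit.

Among the compounds with values here, compound 2 has no number on this read-out, only the limit > 25000 nM, and the one other value shown is a limit as well. The next analogue is compound 3 `CCN(CC)c1ccc(-c2cccc(C#N)c2)nn1`, with cyano in place of trifluoromethyl on an aromatic carbon. The substituent still sits meta to a large group, so the change is confined to this one place.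

Within the data shown here, only one measured step bears on this change: a step that the two limits leave unreadable from compound 1 to compound 2. It also swaps one group for another at this aromatic carbon, but it gives no size to carry over. The evidence amounts to the limit of > 25000 nM in this assay, at which 2 of the 2 values shown sit. Neither compound shows measurable inhibition to build on, so no step beyond the scatter is expected in this assay, and no direction can be assigned. The expected outcome is another limit rather than a number.

The estimated change is a step that the limit leaves unreadable from compound 2 to compound 3. For compound 3 the expected value is 30000 nM, with an estimated range from 12000 nM to 60000 nM.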

Compound 3, half-maximal inhibitory concentration: > 25000 nM
Compound 3: only a limit was reported (the forecaster's own chance of this, stated with the estimate: 85%); the middle value does not contradict the limit.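

In this assay compound 3 gives > 25000 nM, which is a limit. No new step can be read among compound 1, compound 2 and compound 3. The compounds shown leave open whether any group at this aromatic carbon of the shared core gives a measurable value on this read-out, as all that stands so far is this: the limit of > 25000 nM in this assay, at which 3 of the 3 values shown sit.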